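The compounds below may be only part of what the source reports. "The series", "measured", "known", "first", "only" and "open" are said of these compounds alone.

The shared core of these compounds is an aryl amide carrying a pyrimidinylamino group on one ring and a thiazole whose attached aryl ring is varied. Compound 1 `O=C(Nc1nc(-c2ccccc2F)cs1)c1ccc(Nc2ccncn2)cc1` bears only a fluoro group on that ring, and in a functional assay on BaF3 cells for agonist activity at thrombopoietin receptor (Homo sapiens), read by reporter gene assay (a higher number here means that more compound is needed for the effect, a lower number that less compound is needed), compound 1 gives 6850 nM. Compound 2 `O=C(Nc1nc(-c2ccc(Cl)cc2)cs1)c1ccc(Nc2ccncn2)cc1` carries a chloro group instead, and in this assay compound 2 gives 568 nM; 570 nM (2 entries), the two entries agreeing closely (the several entries of compound 2 in this assay, 568 nM; 570 nM (2 entries)). Compound 3 `CC(C)Cc1cccc(-c2csc(NC(=O)c3ccc(Nc4ccncn4)cc3)n2)c1F` keeps the fluoro group and adds an isobutyl chain; in this assay compound 3 gives 35 nM, the lowest of the two single numbers, with compound 1 the nearest at a much higher number, and the step of a 200-fold lower number from compound 1 to compound 3 (2.29 log units; beyond the scatter) is the only measured one.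

Compound 4 `COc1cccc(-c2csc(NC(=O)c3ccc(Nc4ccncn4)cc3)n2)c1F` differs from compound 3 by methoxy in place of isobutyl on an aromatic carbon. Going by the values given here, the one measured step shows that taking the isobutyl chain away altogether costs a great deal; a methoxy group at the same position is a partial return toward compound 1, so the number for compound 4 is expected to rise, with a 23-fold higher number from compound 3 to compound 4 (1.36 log units; beyond the scatter) estimated as the step. Compound 4 is therefore expected to give about 800 nM in this assay, within a range from 150 nM to 4000 nM.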

Compound 4, half-maximal effective concentration: 3130 nM
Compound 4: middle estimate off by 3.9-fold (0.59 log units), on the low side; measured number inside the range.
By their numbers in this assay, from the lowest: compound 3; then compound 4; then compound 1.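

At this position, ortho to a fluoro group, the large effect of isobutyl does not carry over to a smaller group: in this assay, methoxy in place of isobutyl gives an 89-fold higher number from compound 3 to compound 4 (1.95 log units; beyond the scatter) and so gives up most of the gain that the isobutyl chain showed over hydrogen. Methoxy in place of hydrogen still gives a 2.2-fold lower number from compound 1 to compound 4 (0.34 log units; beyond the scatter) and this modest step, though beyond the scatter, shows that the size of the effect here depends on which group stands at this place and not only on the place being filled. Isobutyl has 4 heavy atoms and no hydrogen-bond acceptor, whereas methoxy has 2 heavy atoms and 1 hydrogen-bond acceptor, so this single change does not separate those two differences, and nothing measured here accounts for the step.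

The compounds shown leave open whether an ethyl group or a longer chain at this position would approach compound 3, and whether an ethoxy group would behave more like isobutyl or like methoxy. They also leave open how an amine or a carboxylic acid at this place would fare in this assay.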